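This account rests on a few compounds, and the source may have more. Where it says the series, first, only, none or still open, it means among the compounds named here.

Compound 3 `CS(=O)(=O)c1ccc(N2N=C(c3ccc(-c4ccccc4)cc3)CCC2=O)cc1` gives 6.6% in a functional assay on the whole organism (strain Wistar) for inhibition, with Rattus norvegicus as the target, read by paw edema, with stated times of 30 min and 3 h, at a dose of 0.05 mmol/kg by the oral route (on this read-out higher numbers stand for more inhibition at the one dose given (going by the name of the read-out) and lower numbers for less inhibition), the lowest of the three numbers measured. Compound 2 `CS(=O)(=O)c1ccc(N2N=C(c3ccccc3)CCC2=O)cc1` gives 26.6% and compound 1 `COc1ccc(C2=NN(c3ccc(S(C)(=O)=O)cc3)C(=O)CC2)cc1` gives 46.7% in this assay . The change to compound 4 `CS(=O)(=O)c1ccc(N2N=C(c3ccc(Cl)cc3)CCC2=O)cc1` is chloro in place of phenyl on an aromatic carbon. Within the data shown here, two measured steps bear on it, a number 20 percentage points lower from compound 2 to compound 3 (beyond the scatter) and a number 40.1 percentage points lower from compound 1 to compound 3 (beyond the scatter), both showing that phenyl entering in place of a small group lowered inhibition. Since chloro is a single heavy atom, the reverse is expected, with the step estimated as a number 23.4 percentage points higher from compound 3 to compound 4 (beyond the scatter) in this assay . Compound 4 is therefore estimated at 30%, within a range from 10% to 50%.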

Compound 4, a percentage reported as inhibition, in the whole organism at one dose (the size of the read-out at that dose, not a potency): 26.6%
Compound 4: middle estimate off by 3.4 percentage points, on the high side, and the stated range covers the measured number.
By their numbers in this assay, from the lowest: compound 3; then compounds 2 and 4 (each within the scatter of the next); then compound 1.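

In this assay, chloro in place of phenyl gives a number 20 percentage points higher from compound 3 to compound 4 (beyond the scatter), so a single heavy atom at this place recovers what phenyl lost. Chloro in place of hydrogen gives no change at the digits printed from compound 2 to compound 4 (within the scatter), while chloro in place of methoxy gives a number 20.1 percentage points lower from compound 1 to compound 4 (beyond the scatter), so among these small groups only methoxy stands apart from hydrogen. No evidence is given that explains these differences. The compounds shown leave open whether methoxy's advantage extends to a longer chain such as ethoxy, or to an amine or a hydroxyl group at this place.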